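Replacing a Fluorobenzyl Arm with a Hydroxypropyl Chain

The source may report more compounds than this note shows. Statements on the series, on what has been measured and on what is new or still open speak of the compounds shown alone.

compound 1 `Cc1cc(C)c(Oc2cc(Nc3ccc(C#N)cc3)ncc2C(=O)NCc2cn(Cc3cccc(Cl)c3)nn2)c(C)c1` — 187000 nM
compound 2 `Cc1cc(C)c(Oc2cc(Nc3ccc(C#N)cc3)ncc2C(=O)NCc2cn(Cc3cccc(F)c3)nn2)c(C)c1` — >= 204000 nM

In an ADME assay on MT4 cells (Homo sapiens) for cytotoxicity, read by MTT assay, with a stated time of 5 days (on this read-out higher numbers stand for lower toxicity in this test and lower numbers for higher toxicity in this test), compound 1 gives 187000 nM. For compound 2 this assay reports only a limit, >= 204000 nM. Compound 2 thus stands at the limit of >= 204000 nM in this assay, at which 1 of the 2 values shown sits, and the step of an at least 1.0-fold higher number from compound 1 to compound 2 (0.03 log units; that floor lies within the scatter) is known only as a floor. Compound 3 `Cc1cc(C)c(Oc2cc(Nc3ccc(C#N)cc3)ncc2C(=O)NCc2cn(CCCO)nn2)c(C)c1` is not yet measured; it differs from compound 2 by 2-hydroxyethyl in place of 3-fluorophenyl on a saturated chain carbon bound to an aromatic nitrogen. For the measured compounds named here, the one measured step, an at least 1.0-fold higher number from compound 1 to compound 2 (0.03 log units; that floor lies within the scatter), concerns a fluoro for chloro exchange and so offers no size for the present change, which removes a ring and brings in a hydroxyl chain. With both measured compounds sitting at or near the limit, compound 3 is expected to remain in the same region, with the step of an at least 1.0-fold lower number from compound 2 to compound 3 (0.00 log units; that floor lies within the scatter) expected to show no change beyond the scatter. The estimate for compound 3 is 200000 nM, with a range from 100000 nM to 400000 nM.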

Compound 3, half-maximal cytotoxic concentration: 25200 nM
The estimate for compound 3 lay 7.9-fold (0.90 log units) above the measured number; measured number below the stated range.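

In this assay the place on a saturated chain carbon bound to an aromatic nitrogen proves sensitive to what stands there, which the exchange of one halogen for the other did not reveal: going from 3-fluorobenzyl to 3-hydroxypropyl gives an at least 8.0-fold lower number from compound 2 to compound 3 (0.90 log units; beyond the scatter) and the matching change from the chlorinated arm gives a 7.4-fold lower number from compound 1 to compound 3 (0.87 log units; beyond the scatter). Both steps lie beyond the scatter and point the same way, towards higher toxicity in this test, whichever halogen leaves. The first step is known only as a floor, and the value of compound 2 is a limit: the limit of >= 204000 nM in this assay, at which 1 of the 3 values shown sits.

Going by these compounds, whether the lower number follows the loss of the aromatic ring or the arrival of the hydroxyl stays open, and a plain propyl chain would separate the two. On these data alone, how an amine or a carboxylic acid at the chain end, or a longer chain, would read here also stays open.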